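The source may hold more compounds than are shown below. What is called first, only, known or untested is meant among the compounds shown, and "the series" means these compounds.

Measured in a physicochemical assay for solubility, measured as kinetic solubility, at pH 7.4; a lower number here means a less soluble compound, a higher number a more soluble compound:
- compound 1 `C[C@H](Nc1nccc(Nc2cc(C3CC3)[nH]n2)n1)c1ccc2[nH]ccc2n1`: 133000 nM
- compound 2 `C[C@H](Nc1nccc(Nc2cc(C3CC3)[nH]n2)n1)c1cc2cc[nH]c2cn1`: 73000 nM

Within the data shown here, compound 1 stands level with compound 2, the only other compound measured so far, as the two numbers lie within the scatter of each other. The next compound, compound 3 `C[C@H](Nc1nccc(Nc2cc([C@H]3C[C@@H]3F)[nH]n2)n1)c1ccc2[nH]ccc2n1`, differs from compound 1 by one small edit: fluoro in place of hydrogen on a saturated ring carbon. Put plainly, cyclopropyl becomes 2-fluorocyclopropyl.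

Among the measured compounds shown here, only one measured step is available, a 1.8-fold lower number from compound 1 to compound 2 (0.26 log units; within the scatter). It swaps a different group and leaves the cyclopropyl untouched, so it bears on this edit only indirectly. For the measured compounds named here, no measured compound carries fluoro, so the direction stays open, and no change beyond the scatter is expected. The estimated step is a 1.2-fold lower number from compound 1 to compound 3 (0.08 log units; within the scatter). Compound 3 is expected at 110000 nM, within an estimated range of 50000 nM to 220000 nM.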

Compound 3, solubility: 104000 nM
Estimate against measurement, compound 3: 1.1-fold (0.02 log units) above; the range from low to high includes it.
By their numbers in this assay, from the lowest: compounds 2, 3 and 1 (each within the scatter of the next).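

In this assay, fluoro in place of hydrogen on a saturated ring carbon gives a 1.3-fold lower number from compound 1 to compound 3 (0.11 log units; within the scatter) and so leaves compound 3 level with compound 1. Among these compounds, the earlier pair changed a different group and kept the cyclopropyl as it was, so this is the first direct reading at this ring: a single fluorine atom here produces no difference that can be told from the scatter of repeated measurements. There is no measured evidence that speaks to why the result falls this way.

On these data alone, whether this position stays as tolerant of a larger or charged group, such as an amine or a carboxylic acid, remains open. So does whether swapping the whole cyclopropyl for a longer chain, or for 2-fluorocyclopropyl with its ring carbons in the opposite spatial arrangement, would give a step beyond the scatter.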